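Extending the aryl arm: a phenylethenyl variant of compound 1

The source may hold more compounds than are shown below. What is called first, only, known or untested is meant among the compounds shown, and "the series" means these compounds.

Compound 1 `O=C(CSc1nnc(-c2ccncc2)o1)N/N=C/c1ccc(Br)cc1` was tested in a functional assay on BGC-823 cells (Homo sapiens) for cytotoxicity, read by MTT assay, with a stated time of 48 h (on this read-out higher numbers stand for weaker inhibition and lower numbers for stronger inhibition), where compound 1 gives 24500 nM. Among the three compounds measured so far this is the second highest number; its nearest neighbour is compound 2 `O=C(CSc1nnc(-c2ccncc2)o1)N/N=C/c1cccc(F)c1`, which in this assay gives 27500 nM, a move of a 1.1-fold higher number from compound 1 to compound 2 (0.05 log units; within the scatter). Compound 3 `O=C(CSc1nnc(-c2ccncc2)o1)N/N=C/c1ccc(O)c(O)c1` stands far apart, giving 1260 nM, so that the step is a 19-fold lower number from compound 1 to compound 3 (1.29 log units; beyond the scatter), and from compound 2 the step is a 22-fold lower number from compound 2 to compound 3 (1.34 log units; beyond the scatter).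

Compound 4 `O=C(CSc1nnc(-c2ccncc2)o1)N/N=C/C=C/c1ccccc1` has not yet been measured. The change from compound 1 is 2-phenylethenyl in place of 4-bromophenyl on a carbon with a double bond to nitrogen. Within the data shown here, neither of the large drops bears on this change, since both came with 3,4-dihydroxyphenyl, and no hydroxyl group enters here; the only comparable step, from 4-bromophenyl to 3-fluorophenyl, stayed within the scatter. The expectation for compound 4 is therefore a step of about a 1.2-fold lower number from compound 1 to compound 4 (0.09 log units; within the scatter), not beyond the scatter. Compound 4 is estimated to give 20000 nM in this assay, within a range of 7000 nM to 55000 nM.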

Compound 4, half-maximal inhibitory concentration: 10600 nM
The estimate for compound 4 lay 1.9-fold (0.28 log units) above the measured number; low and high end bracket the measured number.
By their numbers in this assay, from the lowest: compound 3; then compound 4; then compounds 1 and 2 (each within the scatter of the next).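

Unlike the swap from 4-bromophenyl to 3-fluorophenyl, which stayed within the scatter, putting 2-phenylethenyl at this position shifts the result in this assay, giving a 2.3-fold lower number from compound 1 to compound 4 (0.36 log units; beyond the scatter) and a 2.6-fold lower number from compound 2 to compound 4 (0.41 log units; beyond the scatter). So this position can respond to a change that brings in no hydroxyl group, although 2-phenylethenyl does not match 3,4-dihydroxyphenyl, as shown by an 8.4-fold higher number from compound 3 to compound 4 (0.92 log units; beyond the scatter). No measurement is available to explain these steps.

Compound 4 gains a double bond and loses the ring substituent of compound 1 in a single change, so the compounds shown cannot tell which of the two matters. Also open, going by these compounds, is what a 2-phenylethenyl group carrying bromine would give, or a phenyl ring carrying an amine.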